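This account rests on a few compounds, and the source may have more. Where it says the series, first, only, none or still open, it means among the compounds named here.

Measured so far in a physicochemical assay for lipophilicity, read by HPLC, at pH 7.4 (a lower number here means a more polar compound, a higher number a more lipophilic compound), with these results:

Compound 1 `C[C@@H](Oc1cc2ccn(CCC(=O)O)c2cc1Cl)c1ccccn1` gives 2.17 as its reading
Compound 2 `Cc1ccc([C@@H](C)Oc2cc3oc(=O)n(CCC(=O)O)c3cc2Cl)nc1` gives 2.02 as its reading
Compound 3 `COc1cc2oc(=O)n(CCC(=O)O)c2cc1Cl` gives "not determined" (no result reported) as its entry

Going by the values given here, only two of these three compounds therefore carry a number. Compound 2 at 2.02 and compound 1 at 2.17 lie within the scatter of each other, so the two readings cannot be told apart. Compound 3 offers no number to set beside them.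

Attention now turns to compound 4 `Cc1ccnc([C@@H](C)Oc2cc3oc(=O)n(CCC(=O)O)c3cc2Cl)c1`, which has not yet been measured in this assay and which holds the same atoms as compound 2, joined differently. The difference is 4-methylpyridin-2-yl in place of 5-methylpyridin-2-yl on a saturated chain carbon bound to an oxygen on an aromatic ring and a saturated chain carbon and it amounts to 4-methylpyridin-2-yl in place of 5-methylpyridin-2-yl on a saturated chain carbon bound to an oxygen on an aromatic ring and a saturated chain carbon.

Among the compounds with values here, no measured pair of compounds differs in only one place, so the data offer no direct guide to a change of this kind. The account therefore takes compound 2 at 2.02 as its anchor and expects no step beyond the scatter, in either direction. The estimated shift (a number 0.03 log units higher from compound 2 to compound 4 (within the scatter)) is correspondingly small. The reading expected for compound 4 is 2.05 in the middle, with an estimated range running from 1.75 up to 2.35 in all.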

Compound 4, distribution coefficient: 2.15
Estimate against measurement, compound 4: 0.10 log units below; the range from low to high includes it.
By their numbers in this assay, from the lowest: compounds 2, 4 and 1 (each within the scatter of the next).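

Going by these compounds alone, this is the first pair that differs in one place, so it gives a direct reading of a change on a saturated chain carbon bound to an oxygen on an aromatic ring and a saturated chain carbon: with 4-methylpyridin-2-yl in place of 5-methylpyridin-2-yl, this assay shows a number 0.13 log units higher from compound 2 to compound 4 (within the scatter). The two groups match in every count, with the same heavy atoms, the same single hetero atom and the same ring, and at this place the measurement does not tell the two arrangements apart. No other information bears on this result, and the pair alone cannot say what lies behind it.

The compounds shown leave open whether this place would stay as quiet if a group other than methyl sat on the pyridine, such as a primary amine or a trifluoromethyl group, since both groups compared here carry the same methyl. They also leave open whether the same exchange of 5-methylpyridin-2-yl for 4-methylpyridin-2-yl would read alike on the core of compound 1, or with a longer chain in place of the one that carries the carboxylic acid.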